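Benzimidazole Ring-Nitrogen Substituent: Pentyl to Phenyl

This account rests on a few compounds, and the source may have more. Where it says the series, first, only, none or still open, it means among the compounds named here.

Of the compounds shown here, three have been measured in an assay on isolated protein for inhibition of Gonadotropin-releasing hormone receptor (Rattus norvegicus); on this read-out higher numbers stand for weaker inhibition and lower numbers for stronger inhibition.
Compound 1 `Cc1cccc(CSc2nc3cc(NC(=O)C4CC4)ccc3n2C(C)C)c1`: a limit of the assay, > 10000 nM.
Compound 2 `CC(C)n1c(SCc2ccccc2Cl)nc2cc(NC(=O)C3CC3)ccc21`: a limit of the assay, > 10000 nM.
Compound 3 `CCCCCn1c(SCc2cc([N+](=O)[O-])ccc2OC)nc2cc(NC(=O)NC(C)(C)C)ccc21`: 880 nM.

Among the measured compounds shown here, compound 3 stands alone as the only number in this assay; the other two values are limits, (the limit of > 10000 nM in this assay, at which 2 of the 3 values shown sit), so nothing ranks it against them. For the measured compounds named here, the single step between measured compounds, a step that the two limits leave unreadable from compound 1 to compound 2, cannot be read because the limit of > 10000 nM in this assay, at which 2 of the 3 values shown sit, swallows both ends.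

Compound 4 `COc1ccc([N+](=O)[O-])cc1CSc1nc2cc(NC(=O)NC(C)(C)C)ccc2n1-c1ccccc1` differs from compound 3 by phenyl in place of pentyl on an aromatic nitrogen. Going by the values given here, no measured step touches this ring nitrogen; the one step recorded concerns the group on the saturated carbon bound to sulfur and is itself unreadable. There is therefore no measured guide to the size or direction of this change in this assay, and the expectation is that compound 4 stays within the scatter of compound 3, with a wide range on either side. Compound 4 is estimated at 900 nM, between 200 nM and 4000 nM, meaning an expected step of a 1.0-fold higher number from compound 3 to compound 4 (0.01 log units; within the scatter).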

Compound 4, half-maximal inhibitory concentration: > 2600 nM
Compound 4: a limit, no number; the forecaster's own chance of this, stated with the estimate: 15%; middle value at least 2.8-fold (0.46 log units) away from the limit.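

In this assay phenyl in place of pentyl on the aromatic nitrogen gives an at least 2.9-fold higher number from compound 3 to compound 4 (0.47 log units; beyond the scatter) and so gives this position its first readable step. Among the compounds shown here, the change points towards weaker inhibition, whereas the only earlier step, which concerned the group on the saturated carbon bound to sulfur, could not be read. Going by these compounds, how large the step really is remains unknown, for compound 4 gives a limit and not a number: the limit of > 2600 nM in this assay, at which 1 of the 4 values shown sits.

On these data alone, whether a benzyl group, a cyclohexyl ring or a longer chain such as heptyl on this nitrogen would keep the inhibition seen with pentyl stays open. As far as these compounds go, it also stays open whether the step from pentyl to phenyl would have the same direction and size with a different group on the sulfur.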